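Nitro to amino in a sulfonyl-linked stilbene series

The source may report more compounds than this note shows. Statements on the series, on what has been measured and on what is new or still open speak of the compounds shown alone.

Measured compounds:
- compound 1, `COc1cc(/C=C/S(=O)(=O)Cc2ccc(OC)c([N+](=O)[O-])c2)cc(OC)c1`: 16500 nM in a functional assay on MDA-MB-468 cells (Homo sapiens) for cytotoxicity, read by MTT assay, with a stated time of 72 h; a lower number here means a stronger inhibitor of growth, a higher number a weaker inhibitor of growth
- compound 2, `COc1ccc(CS(=O)(=O)CC(=O)Nc2ccccc2)cc1[N+](=O)[O-]`: its result in this assay is a limit, > 30000 nM
- compound 3, `COc1ccc(CS(=O)(=O)CC(=O)Nc2ccccc2)cc1N`: its result in this assay is likewise a limit, > 30000 nM

Within the data shown here, compound 1 is the only compound of the three with a number in this assay. Compounds 2 and 3 both rest at the limit of > 30000 nM in this assay, at which 2 of the 3 values shown sit. The step from compound 2 to compound 3, a step that the two limits leave unreadable from compound 2 to compound 3, is therefore not readable: the two limits do not show whether the change helped or hurt. The difference between the core of compound 1 and the core of compound 2 is not broken down here.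

Compound 4, `COc1cc(/C=C/S(=O)(=O)Cc2ccc(OC)c(N)c2)cc(OC)c1`, is not yet measured. It stands to compound 1 as compound 3 stands to compound 2: the change amino in place of nitro on an aromatic carbon is the same change as amino in place of nitro on an aromatic carbon, and the surroundings of the place are described in the same words in both cases.

Among the measured compounds shown here, since the one measured instance of this change gives no readable size, the expectation for compound 4 can only start from the value of compound 1, 16500 nM, and assume a step of little weight. Compound 4 is therefore expected at about 20000 nM in this assay, between 7000 nM and 30000 nM, which means an estimated step of a 1.2-fold higher number from compound 1 to compound 4 (0.08 log units; within the scatter).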

Compound 4, concentration for 50% growth inhibition: 520 nM
The estimate for compound 4 lay 38-fold (1.59 log units) above the measured number; the whole stated range lies above it.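

The new step in this assay is a 32-fold lower number from compound 1 to compound 4 (1.50 log units; beyond the scatter) for amino in place of nitro on an aromatic carbon, so on the core of this pair the change brings a large gain in growth inhibition. It does not show that the change carries from one core to another, for compound 2 and compound 3 both end in limits, their step cannot be read, and the size of the change on their core can be neither matched with this one nor set against it: the limit of > 30000 nM in this assay, at which 2 of the 4 values shown sit. The finding therefore rests on one readable pair, and nothing shown gives a cause for its size.

The compounds shown leave open whether another group at the same place on an aromatic carbon, such as a hydroxyl, a methylamino or an acetamido group, would hold the gain seen in compound 4 at 520 nM or lose it. They also leave open whether an ethoxy group in place of the methoxy group would alter that result, and whether amino on the other core gives any readable number once that core is changed elsewhere.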